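The source may report more compounds than this note shows. Statements on the series, on what has been measured and on what is new or still open speak of the compounds shown alone.

Measured in a functional assay on MDA-MB-231 cells (Homo sapiens) for antiproliferative activity, read by MTT assay, with a stated time of 72 h, tested at 10 uM; on this read-out higher numbers stand for more inhibition at the one concentration tested (going by the name of the read-out) and lower numbers for less inhibition:

compound 1 `c1ccc(/N=c2\ssnc2-c2ccccc2)cc1` — 0%
compound 2 `CCOC(=O)c1nss/c1=N\c1ccccc1` — 0%
compound 3 `S=c1ssnc1-c1ccccc1` — 0%

Going by the values given here, the one single-point step among the measured compounds, ethoxycarbonyl in place of phenyl on an aromatic carbon, runs no change at the digits printed from compound 1 to compound 2 (within the scatter). Compound 3 stands level with compound 1 and compound 2 at the digits shown; its nearest neighbour is compound 1 and its furthest compound 2, and neither gap reaches beyond the scatter. All three sit at the bottom of the read-out in this assay.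

Compound 4 `Fc1ccc(-c2nssc2=S)cc1` differs from compound 3 by fluoro in place of hydrogen on an aromatic carbon. Among the compounds with values here, no measured step touches this position, so there is nothing that bears on it directly. Within the data shown here, the only measured step, no change at the digits printed from compound 1 to compound 2 (within the scatter), is a larger structural change and moved nothing in this assay, and compound 3 shows the same floor. The expectation is therefore a step of a number 2 percentage points higher from compound 3 to compound 4 (within the scatter), none beyond the scatter. For compound 4 in this assay the estimate is 2%, ranging from 0% to 15%.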

Compound 4, a percentage reported as inhibition, at one concentration (the size of the read-out at that concentration, not a potency): 0%
Beside the measured number, compound 4's estimate is 2 percentage points above it; the range from low to high includes it.
By their numbers in this assay, from the lowest: compounds 1, 2, 3 and 4 (each within the scatter of the next).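

In this assay, going by these compounds alone, the ring position is now probed for the first time: fluoro in place of hydrogen on an aromatic carbon of the six-membered aromatic ring, para to a group of 6 heavy atoms, gives no change at the digits printed from compound 3 to compound 4 (within the scatter) and adds a second step with nothing to read beyond the scatter. Compound 3 and compound 4 both sit at the bottom of the read-out, so this single fluoro does not lift the core off it at the one concentration tested, and a reading at the bottom cannot show any smaller effect. No supporting data bear on why the read-out stays there.

As far as these compounds go, whether an amine, a carboxylic acid or a longer chain at this position would lift the read-out stays open. From the compounds shown here alone, whether any other position on the core responds also stays open.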